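Chloro for Fluoro at a Second Position on the Ring

The source may report more compounds than this note shows. Statements on the series, on what has been measured and on what is new or still open speak of the compounds shown alone.

Of the compounds shown here, three sharing one core have been measured in a functional assay on cells for positive allosteric modulation of G-protein coupled receptor 68 (Homo sapiens), read by a luciferase reporter and cAMP accumulation, with a stated time of 30 min, at pH 6.8 and pH 8.3, in the presence of a further agent that is not named here; a higher number here means a more potent compound, by a factor of ten per unit of this negative logarithm, a lower number a less potent compound. Compound 1 `Nc1nc(NCc2ccccc2)nc(-c2cc(F)ccc2CO)n1` gives 4.58. Compound 3 `Nc1nc(NCc2ccccc2)nc(-c2cc(Cl)ccc2CO)n1` gives 4.49. Compound 2 `Nc1nc(NCc2ccccc2)nc(-c2c(F)cccc2CO)n1` gives 3.69, the lowest of the three; its gap to compound 3 and to compound 1 is beyond the usual scatter in each case.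

Compound 1 and compound 3 differ in one place: chloro in place of fluoro on an aromatic carbon. This gave a number 0.09 log units lower from compound 1 to compound 3 (within the scatter).

Compound 2 has the same atoms as compound 1, joined differently; how the two cores differ is not broken down here.

Compound 4 `Nc1nc(NCc2ccccc2)nc(-c2c(Cl)cccc2CO)n1` has not yet been measured. Against compound 2 its change is chloro in place of fluoro on an aromatic carbon. Among the compounds with values here, this is the same kind of change as the one from compound 1 to compound 3, but not at the same spot: in the earlier pair the changed carbon is meta to a large group and para to a hydroxymethyl group, whereas here it is ortho to a large group and meta to a hydroxymethyl group.

The expectation for compound 4 rests on the earlier pair, where the step was a number 0.09 log units lower from compound 1 to compound 3 (within the scatter), so a step of about a number 0.09 log units lower from compound 2 to compound 4 (within the scatter) from compound 2 is estimated, though the different surroundings widen the uncertainty. For compound 4 in this assay the estimated value is 3.6, expected to lie between 3.1 and 4.1.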

Compound 4, negative logarithm of the antagonist equilibrium constant: 4.43
Compound 4: the middle estimate sits 0.83 log units below what was measured; measured number above the stated range.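

Chloro in place of fluoro, on the aromatic carbon that is ortho to a large group and meta to a hydroxymethyl group, gave a number 0.74 log units higher from compound 2 to compound 4 (beyond the scatter) in this assay. This means the change cannot simply be carried from one core to the other in this series, as the two steps set side by side make plain: the same change on two cores in this assay, a number 0.09 log units lower (within the scatter) from compound 1 to compound 3 and a number 0.74 log units higher (beyond the scatter) from compound 2 to compound 4, 0.83 log units apart, beyond the scatter of two such steps. What this does not show is the reason for the difference: the change sits at a different spot on the ring in each pair, and two pairs cannot tell whether that spot or something else about the cores decides the outcome, nor do they say how any other change would carry over.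

The compounds shown leave open whether a bromo, a methyl or a methoxy group on that same carbon would give a number closer to that of compound 2 or to that of compound 4. They also leave open whether the step seen with chloro would hold if the hydroxymethyl group gave way to an amine or a carboxylic acid, or if the benzyl group on the shared core were replaced by a longer chain.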